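The compounds below may be only part of what the source reports. "The series", "measured", "known", "first", "only" and "open" are said of these compounds alone.

In a functional assay on MGC-803 cells (Homo sapiens) for antiproliferative activity, read by MTT assay, with a stated time of 72 h (on this read-out lower numbers stand for stronger inhibition and higher numbers for weaker inhibition), compound 1 `COc1ccc(-c2nc(CNc3ccc(C(=O)NO)cc3)n(-c3ccccc3)n2)cc1` gives only a limit, > 20000 nM. Compound 2 `O=C(NO)c1ccc(NCc2nc(-c3ccccc3)nn2-c2cccc(Cl)c2)cc1` gives 13700 nM in this assay, and compound 3 `Cc1ccsc1-c1nc(CNc2ccc(C(=O)NO)cc2)n(-c2ccccc2)n1` gives 8890 nM. Among the two numbers shown, compound 3 stands lowest, though compound 2 sits within the scatter of it, so no order between them can be read. One measured step reaches compound 3: an at least 2.2-fold lower number from compound 1 to compound 3 (0.35 log units; beyond the scatter), where the starting point is a limit, as the limit of > 20000 nM in this assay, at which 1 of the 3 values shown sits, records.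

Compound 4 `O=C(NO)c1ccc(NCc2nc(-c3ccccc3)nn2-c2ccccc2)cc1` differs from compound 3 as follows: phenyl in place of 3-methylthiophen-2-yl on an aromatic carbon. The step from compound 1 to compound 3 concerned the same place but a different leaving group, so it bears on the change only loosely. Compound 2 also carries phenyl on that aromatic carbon and gives a number within the scatter of compound 3. Compound 4 is therefore expected to land near both, with a 1.2-fold higher number from compound 3 to compound 4 (0.09 log units; within the scatter), as a step not beyond the scatter. The estimated value of compound 4 in this assay is 11000 nM, within 5000 nM to 25000 nM.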

Compound 4, half-maximal inhibitory concentration: 17700 nM
Estimate against measurement, compound 4: 1.6-fold (0.21 log units) below; the measured number falls inside the stated range.
By their numbers in this assay, from the lowest: compounds 3, 2 and 4 (each within the scatter of the next). At a limit, above all of these: compound 1.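

In this assay, the change on the aromatic carbon between two ring nitrogen atoms gives a 2.0-fold higher number from compound 3 to compound 4 (0.30 log units; within the scatter), so this position does not separate phenyl from 3-methylthiophen-2-yl. Hydrogen in place of chloro gives a 1.3-fold higher number from compound 2 to compound 4 (0.11 log units; within the scatter), so the chloro group makes no readable difference either. Hydrogen in place of methoxy gives an at least 1.1-fold lower number from compound 1 to compound 4 (0.05 log units; that floor lies within the scatter), but this step starts from the value of compound 1, which is only a limit, so it fixes no order: the limit of > 20000 nM in this assay, at which 1 of the 4 values shown sits.

The compounds shown leave open whether an amine or a carboxylic acid on that aromatic carbon would move the number beyond the scatter. They also leave open whether a longer chain there, in place of the ring, would do so.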